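The source may hold more compounds than are shown below. What is called first, only, known or untested is meant among the compounds shown, and "the series" means these compounds.

Of the compounds shown here, three have so far been tested in an assay on isolated protein for inhibition of tyrosine-protein kinase receptor UFO (Homo sapiens), with a stated time of 1.5 h; on this read-out lower numbers stand for stronger inhibition and higher numbers for weaker inhibition. Compound 1 `Cc1cnc2[nH]ccc2c1Cl` gives 20200 nM, compound 2 `FC(F)(F)c1cccc2[nH]ncc12` gives 184000 nM, and compound 3 `Cn1cc(-c2n[nH]c3ccc(N)cc23)cn1` gives 8910 nM. Compound 3 thus has the lowest of the three numbers; compound 1 stands nearest to it and compound 2 furthest, both gaps lying beyond the scatter. Compound 4 `Cn1cc(-c2n[nH]c3ccc(Nc4ccccc4)cc23)cn1` differs from compound 3 by phenyl in place of hydrogen on a nitrogen on an aromatic ring. Going by the values given here, no pair of measured compounds shows such a change, so the expectation rests on the structural change alone: adding an aromatic ring to a compound of this size is expected to lower the number in this assay by a moderate step, beyond the scatter. Compound 4 is therefore expected to give 2500 nM, within 400 nM to 12000 nM. The expected step is a 3.6-fold lower number from compound 3 to compound 4 (0.55 log units; beyond the scatter).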

Compound 4, half-maximal inhibitory concentration: 580 nM
For compound 4 the middle estimate is 4.3-fold (0.63 log units) above the measured one; low and high end bracket the measured number.
By their numbers in this assay, from the lowest: compound 4; then compound 3; then compound 1; then compound 2.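

Putting phenyl in place of hydrogen on this nitrogen, the change from amino to anilino, gives a 15-fold lower number from compound 3 to compound 4 (1.19 log units; beyond the scatter) in this assay, a large step beyond the scatter. Going by these compounds alone, this is the first comparison here of two compounds differing in one place, and it shows that this nitrogen can carry a whole aromatic ring with stronger inhibition as the result. Nothing measured here explains the size of this step. Still open, from the compounds shown here alone, is whether the ring itself matters, or whether a smaller group such as methyl would do the same. A phenyl bearing an amine or a carboxylic acid would show whether the new ring tolerates further groups.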